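The compounds below may be only part of what the source reports. "The series", "measured", "known", "first", "only" and "open" are said of these compounds alone.

Compound 1 `O=C1c2c[n+]([O-])c3ccccc3c2C(=O)c2c1c1ccccc1n2Cc1cn(CC(O)CO)nn1`: in a functional assay on HCT-116 cells (Homo sapiens) for cytotoxicity, read by MTT assay, with a stated time of 72 h (a lower number here means a stronger inhibitor, a higher number a weaker inhibitor), compound 1 gives 250 nM.
Compound 2 `O=C1c2c[n+]([O-])c3ccccc3c2C(=O)c2c1c1ccccc1n2CCN1CCCC1`: in this assay compound 2 gives 270 nM.
Compound 3 `O=C1c2c[n+]([O-])c3ccccc3c2C(=O)c2c1c1ccccc1n2CCN1CCCCC1`: in this assay compound 3 gives 780 nM.

Compound 1 gives the lowest of these three numbers, but its gap to compound 2 is within the scatter, a 1.1-fold higher number from compound 1 to compound 2 (0.03 log units; within the scatter), so those two cannot be put in order; only compound 3 stands apart from compound 1, a 3.1-fold higher number from compound 1 to compound 3 (0.49 log units; beyond the scatter). Compound 4 `O=C1c2c[n+]([O-])c3ccccc3c2C(=O)c2c1c1ccccc1n2CCCN1CCC(O)CC1` has not yet been measured. It arises from compound 1 by a single change: 2-(4-hydroxypiperidin-1-yl)ethyl in place of 1-(2,3-dihydroxypropyl)-1H-1,2,3-triazol-4-yl on a saturated chain carbon bound to an aromatic nitrogen. The measured steps that bear on this all concern what sits on the saturated chain carbon bound to the aromatic nitrogen. Swapping the triazolyl group for a ring attached through nitrogen left the number unchanged when that ring was pyrrolidine, yet cost modestly when it was piperidine, and the piperidine-for-pyrrolidine exchange alone shows the same modest loss, a 2.9-fold higher number from compound 2 to compound 3 (0.46 log units; beyond the scatter). Since compound 4 carries a piperidine ring, compound 4 is expected to show a modest rise in the number, a 2.2-fold higher number from compound 1 to compound 4 (0.34 log units; beyond the scatter). Compound 4 is therefore estimated at 550 nM, within 250 nM to 1200 nM.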

Compound 4, half-maximal inhibitory concentration: 190 nM
For compound 4 the middle estimate is 2.9-fold (0.46 log units) above the measured one, outside the stated range (below it).
By their numbers in this assay, from the lowest: compounds 4, 1 and 2 (each within the scatter of the next); then compound 3.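

A piperidine ring on this chain carries no fixed penalty in this assay: the 3-(4-hydroxypiperidin-1-yl)propyl group of compound 4 more than offsets the loss seen with compound 3 (a 4.1-fold lower number from compound 3 to compound 4 (0.61 log units; beyond the scatter)). Compound 4 cannot be separated from compound 1 (a 1.3-fold lower number from compound 1 to compound 4 (0.12 log units; within the scatter)) or from compound 2 (a 1.4-fold lower number from compound 2 to compound 4 (0.15 log units; within the scatter)), so this position tolerates all three of these quite different groups. Nothing measured here explains why the number falls with this group.

Compound 4 differs from compound 3 in both the added hydroxyl and the longer chain, so the compounds shown cannot say which of the two matters. A plain piperidine on a propyl chain, or a 4-hydroxypiperidine on an ethyl chain, would separate the two.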